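Two Trifluoromethyl Groups on the Benzyl Ring

The compounds below may be only part of what the source reports. "The series", "measured", "known", "first", "only" and "open" are said of these compounds alone.

Of the compounds shown here, three have been measured in an assay on CHO-K1 cells for displacement of a labelled ligand from prostaglandin E2 receptor EP1 subtype (Homo sapiens); a higher number here means a weaker inhibitor, a lower number a stronger inhibitor. Compound 1 `O=C(O)c1ccn(Cc2cc(Br)ccc2OCc2ccccc2)n1` gives 9.77 nM. Compound 2 `O=C(O)c1nn(Cc2cc(Br)ccc2OCc2ccccc2)cc1C(F)(F)F` carries one extra group, (trifluoromethyl in place of hydrogen on an aromatic carbon), and in this assay compound 2 gives 2570 nM, so that a 260-fold higher number from compound 1 to compound 2 (2.42 log units; beyond the scatter). Compound 3 `Cc1cc(C(=O)O)nn1Cc1cc(Br)ccc1OCc1cccc(C(F)(F)F)c1` gives 309 nM in this assay; the difference between the core of compound 3 and the core of compound 1 is not broken down here.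

Compound 4 `Cc1cc(C(=O)O)nn1Cc1cc(Br)ccc1OCc1cc(C(F)(F)F)cc(C(F)(F)F)c1` is not yet measured. It differs from compound 3 by trifluoromethyl in place of hydrogen on an aromatic carbon. Going by the values given here, this is the same kind of change as the one from compound 1 to compound 2, but not the same: there the entering group sat on a five-membered aromatic ring with 2 nitrogen, next to the ring atom that bears a carboxy group, whereas here it sits on a six-membered aromatic ring of carbon only, meta to a large group and meta to a trifluoromethyl group. The earlier step is therefore a weak guide. Compound 4 is expected to show a 1.9-fold higher number from compound 3 to compound 4 (0.29 log units; within the scatter), a much smaller step, and the estimate for compound 4 is 600 nM, with a range from 150 nM to 2500 nM.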

Compound 4, half-maximal inhibitory concentration: 5250 nM
Estimate against measurement, compound 4: 8.8-fold (0.94 log units) below; measured number above the stated range.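

In this assay, the second trifluoromethyl group on the benzyl ring gives a 17-fold higher number from compound 3 to compound 4 (1.23 log units; beyond the scatter), so here too the added group goes with a weaker inhibitor. The direction of the change carries over between these two cores, but its size does not: the same change on two cores in this assay, a 260-fold higher number (2.42 log units; beyond the scatter) from compound 1 to compound 2 and a 17-fold higher number (1.23 log units; beyond the scatter) from compound 3 to compound 4, 15-fold (1.19 log units) apart, beyond the scatter of two such steps

Two steps cannot tell whether this gap comes from the ring that takes up the new group or from the rest of the core, and they give no rule for any further core.

The compounds shown leave open whether a smaller substituent in the same place, such as a chlorine atom or a methoxy group, would raise the number as far as trifluoromethyl does. Also open, as far as these compounds go, is whether the same second trifluoromethyl group would cost as much on the core of compound 1, which has a far lower number to begin with.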